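A few compounds are considered here, and "the series" means these few. Any claim that something is new, unique, unknown or untested is made for them only; others in the source may bear on it.

In a functional assay on SW480 cells (Homo sapiens) for antiproliferative activity, read by sulforhodamine B assay, with a stated time of 48 h (a lower number here means a stronger inhibitor, a higher number a weaker inhibitor), compound 1 `COc1ccc(C(=O)/C=C/c2ccccc2-c2ccc(F)cc2)cc1` gives 8400 nM and compound 2 `O=C(/C=C/c1ccccc1-c1ccc(F)cc1)c1cccc(O)c1` gives 8700 nM, so compound 2 stands level with compound 1 within the scatter. Within the data shown here, the one measured step, a 1.0-fold higher number from compound 1 to compound 2 (0.02 log units; within the scatter), exchanges 4-methoxyphenyl for 3-hydroxyphenyl on a carbonyl carbon. Compound 3 `COc1ccc(C(=O)/C=C/c2ccccc2-c2ccc(F)cc2)cc1O` differs from compound 2 by methoxy in place of hydrogen on an aromatic carbon, ortho to a hydroxy group, and so carries both groups. Because of the small step of a 1.0-fold higher number from compound 1 to compound 2 (0.02 log units; within the scatter), no change beyond the scatter is expected in this assay. The expected shift is a 1.3-fold lower number from compound 2 to compound 3 (0.13 log units; within the scatter). The estimate for compound 3 is 6500 nM, within an expected range of 2800 nM to 14000 nM.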

Compound 3, half-maximal inhibitory concentration: 340 nM
Estimate against measurement, compound 3: 19-fold (1.28 log units) above; the measured number lies below the stated range.
By their numbers in this assay, from the lowest: compound 3; then compounds 1 and 2 (each within the scatter of the next).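

In this assay, the two compounds carrying one of the groups stand level, yet adding the second group gives a 26-fold lower number from compound 2 to compound 3 (1.41 log units; beyond the scatter) for methoxy and a 25-fold lower number from compound 1 to compound 3 (1.39 log units; beyond the scatter) for hydroxy. Among these three compounds, the large drop appears only where methoxy stands ortho to a hydroxy group on the same ring, so neither change can be judged apart from the other. No measurement offered here accounts for this drop.

Going by these compounds, whether an amine could take the place of the hydroxy group remains open. So does whether ethoxy, a longer chain, would hold the number in place of methoxy.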